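This account rests on a few compounds, and the source may have more. Where it says the series, first, only, none or still open, it means among the compounds named here.

Measured so far:
- compound 1 `CCn1ccc2cc(/C(=N\O)c3cc(OC)c(OC)c(OC)c3)ccc21` — in a functional assay on HL-60 cells (Homo sapiens) for cytotoxicity, read by XTT assay, with a stated time of 72 h (a lower number here means a stronger inhibitor, a higher number a weaker inhibitor), compound 1 gives > 1000 nM, which is a limit of the assay and not a number.
- compound 2 `COc1cc(/C(=N/OC(C)=O)c2ccc3c(ccn3C)c2)cc(OC)c1OC` — in this assay compound 2 gives > 10000 nM, again a limit and not a number.

Among the measured compounds shown here, compound 2 therefore stands at the weaker end of what this assay can report: of the two values shown, one sits at the limit of > 10000 nM in this assay, at which 1 of the 2 values shown sits, and the other at the limit of > 1000 nM in this assay, at which 1 of the 2 values shown sits, so neither gives a number to compare against, and no step between measured compounds can be drawn.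

Compound 3 `COc1cc(/C(=N\OC(C)=O)c2ccc3c(ccn3C)c2)cc(OC)c1OC` is the next compound. Compared with compound 2, (the two compounds have the same atoms and bonds and differ only in configuration as drawn: 1 of 1 stereo elements differ; a double bond is drawn E in compound 2 and Z in compound 3). For the measured compounds named here, the geometry of the drawn double bond is the only thing that changes.

Going by the values given here, with compound 2 known only as a limit in this assay, no measured step tells how large a change in drawn configuration makes. The step from compound 2 to compound 3 is therefore an open expectation: it could be none beyond the scatter, or a move to a stronger inhibitor. The estimate for compound 3 is 3000 nM, with a range from 300 nM to 30000 nM, which means an expected step of an at least 3.3-fold lower number from compound 2 to compound 3 (0.52 log units; beyond the scatter).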

Compound 3, half-maximal inhibitory concentration: > 10000 nM
Compound 3 gave a limit, no number; the forecaster's own chance of this, stated with the estimate: 50%; at least 3.3-fold (0.52 log units) between middle value and limit.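

In this assay compound 3 gives > 10000 nM, a limit and not a number. Compound 2 is also known only as a limit, so no step can be read between compound 2 and compound 3. The compounds shown leave open whether the drawn geometry of the double bond changes the result in this assay at all.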